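This account rests on a few compounds, and the source may have more. Where it says the series, first, only, none or still open, it means among the compounds named here.

Working notes on the series. Compound 1 `Oc1cccc(-c2cc(-c3cccc(F)c3)cc(-c3cccc(O)c3)n2)c1` carries a fluoro group on the central aromatic carbon and in a functional assay on DU-145 cells (Homo sapiens) for inhibition (a lower number here means a stronger inhibitor, a higher number a weaker inhibitor), compound 1 gives 23800 nM. Compound 2 `Oc1cccc(-c2cc(-c3cccc(C(F)(F)F)c3)cc(-c3cccc(O)c3)n2)c1` differs by a trifluoromethyl in place of that fluoro. In this assay compound 2 reaches only the limit of > 50000 nM, so no number is known for it. The step of an at least 2.1-fold higher number from compound 1 to compound 2 (0.32 log units; beyond the scatter) is therefore itself only a lower bound, set by the limit of > 50000 nM in this assay, at which 1 of the 2 values shown sits.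

Compound 3 `Oc1cccc(-c2cc(-c3ccc(C(F)(F)F)cc3)cc(-c3cccc(O)c3)n2)c1` is the next member. Its change from compound 2 is 4-(trifluoromethyl)phenyl in place of 3-(trifluoromethyl)phenyl on an aromatic carbon: the same atoms, joined differently, so that the trifluoromethyl moves within the phenyl ring while the two 3-hydroxyphenyl groups stay untouched. Going by the values given here, no measured step compares two positions of the same group, so the only guidance is the weak standing of compound 2 at the limit. With nothing to suggest a recovery, the step that the limit leaves unreadable from compound 2 to compound 3 is expected to be small, within the scatter in either direction. Compound 3 is accordingly estimated at 55000 nM, with a range from 20000 nM to 150000 nM, and a good chance that this assay again reports only a limit for compound 3.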

Compound 3, half-maximal inhibitory concentration: 33500 nM
Compound 3: middle estimate off by 1.6-fold (0.22 log units), on the high side, within the range that was stated.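

In this assay, going by these compounds alone, compound 3 provides the first number for a trifluoromethyl-bearing phenyl at this position, opposite the ring nitrogen, so a trifluoromethyl on this phenyl does not by itself put a compound at the limit of the assay. The step of an at least 1.4-fold lower number from compound 2 to compound 3 (0.17 log units; that floor lies within the scatter) is only a floor, and the true gap between the 3-(trifluoromethyl)phenyl and 4-(trifluoromethyl)phenyl placements cannot be read: the limit of > 50000 nM in this assay, at which 1 of the 3 values shown sits. The step of a 1.4-fold higher number from compound 1 to compound 3 (0.15 log units; within the scatter) lies within the scatter, and 3-fluorophenyl and 4-(trifluoromethyl)phenyl cannot be told apart here, which leaves no readable gain or loss between these two groups.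

Still open, as far as these compounds go, is whether any group at this position can bring the number clearly below those of compound 1 and compound 3, for example an amine or a carboxylic acid on this phenyl, or a longer chain in place of the trifluoromethyl. Every compound shown carries both 3-hydroxyphenyl groups, and their contribution to the reading in this assay remains unknown.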